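Compound 3 to compound 4: a change on the aryl group

The source may report more compounds than this note shows. Statements on the series, on what has been measured and on what is new or still open speak of the compounds shown alone.

In a functional assay on SW-620 cells (Homo sapiens) for cytotoxicity, read by MTT assay, with a stated time of 72 h (on this read-out higher numbers stand for weaker inhibition and lower numbers for stronger inhibition), compound 1 (`COc1cccc(/C=C2\CCC/C(=C\c3cccc(Cl)c3)C2=O)c1OC`) gives 9100 nM, compound 2 (`COc1cccc(/C=C2\CCC/C(=C\c3ccccc3Br)C2=O)c1OC`) gives 12100 nM and compound 3 (`COc1cccc(/C=C2\CCC/C(=C\c3cccc(O)c3)C2=O)c1OC`) gives 6400 nM. Compound 3 therefore stands within the scatter of both other compounds, and the three numbers cannot be ranked.

Compound 4 (`COc1cc(/C=C2\CCC/C(=C\c3cccc(OC)c3OC)C2=O)ccc1O`) differs from compound 3 at one place: 4-hydroxy-3-methoxyphenyl in place of 3-hydroxyphenyl on a double-bonded chain carbon bound to a double-bonded ring carbon. The group changes on a double-bonded chain carbon bound to a double-bonded ring carbon, and the shared core stays the same. Going by the values given here, no measured compound carries the 4-hydroxy-3-methoxyphenyl group, so the evidence is indirect.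

The relevant steps are those that alter the same aromatic group: a 1.3-fold higher number from compound 1 to compound 2 (0.12 log units; within the scatter), a 1.4-fold lower number from compound 1 to compound 3 (0.15 log units; within the scatter) and a 1.9-fold lower number from compound 2 to compound 3 (0.28 log units; within the scatter). All three stay within the scatter, so among these three compounds, exchanging chloro, bromo and hydroxy substituents has not shifted this assay measurably. None of the compounds goes against this, but the set is small and the new group is larger than those tested.

The expected change is a 1.0-fold higher number from compound 3 to compound 4 (0.01 log units; within the scatter), which means no shift beyond the scatter is anticipated in either direction. For compound 4 the estimated value is 6500 nM, with an expected range of 2500 nM to 15000 nM.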

Compound 4, half-maximal inhibitory concentration: 8600 nM
Compound 4: middle estimate off by 1.3-fold (0.12 log units), on the low side; the measured number falls inside the stated range.
By their numbers in this assay, from the lowest: compounds 3, 4, 1 and 2 (each within the scatter of the next).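

In this assay, the 4-hydroxy-3-methoxyphenyl group on a double-bonded chain carbon bound to a double-bonded ring carbon stays within the scatter of all three earlier aryl groups: a 1.3-fold higher number from compound 3 to compound 4 (0.13 log units; within the scatter), a 1.4-fold lower number from compound 2 to compound 4 (0.15 log units; within the scatter) and a 1.1-fold lower number from compound 1 to compound 4 (0.02 log units; within the scatter). The earlier compounds shown here showed this flat picture only for exchanges among chloro, bromo and hydroxy substituents, whereas this change brings in a group with more heavy atoms and one more hydrogen-bond acceptor than the 3-hydroxyphenyl group it replaces. Among these four compounds, none goes against the flat picture at this position, and no compound can be ranked above another. No measurement at hand offers an explanation for this lack of movement.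

The compounds shown leave open whether any aryl group at this position can move the number beyond the scatter, for example one carrying an amine or a carboxylic acid. They also leave open whether the same flat picture holds when the dimethoxyphenyl group shared by all four compounds is exchanged for another group.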